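The source may hold more compounds than are shown below. What is called first, only, known or untested is meant among the compounds shown, and "the series" means these compounds.

Of the compounds shown here, two have been measured so far in a functional assay on ZR-75-1 cells (Homo sapiens) for inhibition, read by sulforhodamine B assay; a higher number here means a weaker inhibitor of growth, a lower number a stronger inhibitor of growth. Compound 1 `c1ccc(-c2ccc(-c3ccc(-c4nc5ccccc5[nH]4)cc3)cc2)cc1` gives 100000 nM, the higher of the two numbers, and compound 2 `COc1ccc(-c2ccc(-c3ccc(-c4nc5cc(C)ccc5[nH]4)cc3)cc2)cc1OC` gives 3100 nM, a gap well beyond the scatter. Compound 1 therefore stands at the weak end of what has been measured in this series.

The next compound is compound 3 `FC(F)(F)c1ccc(-c2ccc(-c3ccc(-c4nc5ccccc5[nH]4)cc3)cc2)cc1`, which carries trifluoromethyl in place of hydrogen on an aromatic carbon, para to a large group: trifluoromethyl in place of hydrogen on an aromatic carbon. The same difference reads phenyl to 4-(trifluoromethyl)phenyl.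

Among the compounds with values here, no measured pair differs in one place only, so the change has no direct precedent here. A modest step toward a lower number is expected in this assay, probably only just beyond the scatter, and no change beyond the scatter would not be a surprise. That direction rests only on compound 1 at 100000 nM being the top of the measured range. The expected step is a 3.3-fold lower number from compound 1 to compound 3 (0.52 log units; beyond the scatter). For compound 3 the estimate is 30000 nM, with an expected range of 8000 nM to 100000 nM.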

Compound 3, concentration for 50% growth inhibition: 48300 nM
Compound 3: middle estimate off by 1.6-fold (0.21 log units), on the low side; the measured number falls inside the stated range.
By their numbers in this assay, from the lowest: compound 2; then compound 3; then compound 1.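

In this assay, within the data shown here, trifluoromethyl in place of hydrogen on an aromatic carbon, para to a large group, gives a 2.1-fold lower number from compound 1 to compound 3 (0.32 log units; beyond the scatter) in the first pair of this series that differs in one place only. The position therefore accepts a group of 4 heavy atoms without a rise in the number, and the change moves it modestly downward, although compound 3 still stands at 48300 nM in this assay. The data offer no measurement that bears on the reason for this step.

On these data alone, whether the step is specific to trifluoromethyl remains open, as a chlorine atom, a nitrile, an amine or a carboxylic acid at the same place could give a smaller step, a larger one or a step in the opposite direction. As far as these compounds go, compound 2 differs from compound 1 in more than one place, so its number cannot be divided among its changes, and it remains unknown whether trifluoromethyl would give a similar step on the core of compound 2.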